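This account rests on a few compounds, and the source may have more. Where it says the series, first, only, none or still open, it means among the compounds named here.

Measured so far, in an assay on isolated protein for displacement of a labelled ligand from Oxytocin receptor (Homo sapiens); a higher number here means a weaker inhibitor, a lower number a stronger inhibitor: compound 1 `CC[C@H](C)[C@@H]1C(=O)N[C@H](C2Cc3ccccc3C2)C(=O)N1[C@@H](C(=O)N1CCOCC1)c1cnc(C)cc1C` gives 0.0501 nM; compound 2 `CC[C@H](C)[C@@H]1C(=O)N[C@H](C2Cc3ccccc3C2)C(=O)N1[C@@H](C(=O)N(C)C)c1ccc(C)nc1C` gives 0.0794 nM; compound 3 `CC[C@H](C)[C@@H]1C(=O)N[C@H](C2Cc3ccccc3C2)C(=O)N1[C@@H](C(=O)N(C)C)c1ccc(C)[n+]([O-])c1` gives 1 nM.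

Compound 3 stands highest of the three, the weakest inhibitor of the set; compound 2 lies nearest to it and compound 1 furthest. Compound 4 `CC[C@H](C)[C@@H]1C(=O)N[C@H](C2Cc3ccccc3C2)C(=O)N1[C@@H](C(=O)N(C)C)c1cnc(C)cc1C` differs from compound 3 by a group of 8 heavy atoms (7 carbon, 1 nitrogen; one six-membered aromatic ring with 1 hetero atom) in place of a group of 8 heavy atoms (6 carbon, 1 nitrogen, 1 oxygen; one six-membered aromatic ring with 1 hetero atom), on a saturated chain carbon bound to an amide-type nitrogen in a ring and a carbonyl carbon. Among the compounds with values here, the one measured step that bears on this is a 13-fold higher number from compound 2 to compound 3 (1.10 log units; beyond the scatter), where the group that now leaves compound 3 entered and the number rose sharply. Reversing that entry is expected to undo most of the rise, bringing compound 4 back toward compounds 1 and 2. For compound 4 the estimated step is a 16-fold lower number from compound 3 to compound 4 (1.20 log units; beyond the scatter). Compound 4 is therefore expected to give 0.063 nM, within 0.025 nM to 0.16 nM.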

Compound 4, inhibition constant: 0.0398 nM
Beside the measured number, compound 4's estimate is 1.6-fold (0.20 log units) above it; the measured number falls inside the stated range.
By their numbers in this assay, from the lowest: compounds 4, 1 and 2 (each within the scatter of the next); then compound 3.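

In this assay, putting 4,6-dimethylpyridin-3-yl in place of the oxygen-bearing ring group gives a 25-fold lower number from compound 3 to compound 4 (1.40 log units; beyond the scatter), so the loss seen with that group is not a general feature of this position. Exchanging 2,6-dimethylpyridin-3-yl for 4,6-dimethylpyridin-3-yl gives a 2.0-fold lower number from compound 2 to compound 4 (0.30 log units; within the scatter), and dimethylamino in place of morpholin-4-yl on the carbonyl carbon gives a 1.3-fold lower number from compound 1 to compound 4 (0.10 log units; within the scatter), so both changes are tolerated here. Nothing measured here explains these results.

On these data alone, whether a plain phenyl ring would hold the number as low remains open. So does whether the oxygen alone, rather than the changed methyl pattern, accounts for the large step.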